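Aryl swap on the ring nitrogen: expectation for compound 4

The source may report more compounds than this note shows. Statements on the series, on what has been measured and on what is new or still open speak of the compounds shown alone.

Values measured in a functional assay on HOS-TE85 cells (Homo sapiens) for inhibition, read by CCK-8 assay, with a stated time of 72 h, tested at 1 uM; a higher number here means more inhibition at the concentration tested (going by the name of the read-out), a lower number less inhibition:
compound 1 `O=C(NCCCCc1ccccc1)c1cccc(C2SCC(=O)N2c2ccccc2)c1` gives 96%
compound 2 `CCN1C(=O)CSC1c1cccc(C(=O)NCCCCc2ccccc2)c1` gives 0%
compound 3 `COc1cc(F)ccc1N1C(=O)CSC1c1cccc(C(=O)NCCCCc2ccccc2)c1` gives 94%

Compound 3 stands second highest of the three numbers. Its nearest neighbour is compound 1, with a number 2 percentage points lower from compound 1 to compound 3 (within the scatter), a step within the scatter. Its furthest is compound 2, with a number 94 percentage points higher from compound 2 to compound 3 (beyond the scatter), a large step beyond the scatter.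

Compound 4 `O=C(NCCCCc1ccccc1)c1cccc(C2SCC(=O)N2c2cccc(F)c2)c1` is the next member. It differs from compound 3 as follows: 3-fluorophenyl in place of 4-fluoro-2-methoxyphenyl on an amide-type nitrogen in a ring.

Among the compounds with values here, two measured steps bear on this change, both at the same amide-type nitrogen in the ring. The step of a number 96 percentage points lower from compound 1 to compound 2 (beyond the scatter) shows that removing the six-membered aromatic ring of carbon only from that nitrogen costs nearly all inhibition. The step of a number 2 percentage points lower from compound 1 to compound 3 (within the scatter) shows that exchanging one such ring for another ring of the same kind leaves the number within the scatter. The change to compound 4 keeps a six-membered aromatic ring of carbon only on the nitrogen, so the expected step of a number 2 percentage points lower from compound 3 to compound 4 (within the scatter) is no change beyond the scatter. Compound 4 is therefore estimated at 92%, within 75% to 100%.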

Compound 4, a percentage reported as inhibition, at one concentration (the size of the read-out at that concentration, not a potency): 94%
Compound 4: middle estimate off by 2 percentage points, on the low side; low and high end bracket the measured number.
By their numbers in this assay, from the lowest: compound 2; then compounds 3, 4 and 1 (each within the scatter of the next).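

In this assay fluoro in place of hydrogen on an aromatic carbon gives a number 2 percentage points lower from compound 1 to compound 4 (within the scatter) and 3-fluorophenyl in place of 4-fluoro-2-methoxyphenyl gives no change at the digits printed from compound 3 to compound 4 (within the scatter), so on the amide-type nitrogen in the ring the series now holds three differently substituted phenyl groups with no difference beyond the scatter, and the methoxy group of compound 3 is not required for this level of inhibition. The contrast with the ethyl group also holds for a second substituted ring, with 3-fluorophenyl in place of ethyl giving a number 94 percentage points higher from compound 2 to compound 4 (beyond the scatter). Nothing available explains these numbers.

As far as these compounds go, a cyclohexyl or benzyl group on that nitrogen would test whether an aromatic ring directly on it is needed, and a pyridyl ring or a carboxylic acid on the phenyl ring remains open. From the compounds shown here alone, with readings at one concentration only, how the effects of compound 1, compound 3 and compound 4 compare at other concentrations also remains open.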